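A few compounds are considered here, and "the series" means these few. Any claim that something is new, unique, unknown or untested is made for them only; others in the source may bear on it.

Measured so far in an assay on cells for inhibition of Palmitoleoyl-protein carboxylesterase NOTUM variant C330S (Homo sapiens), read by fluorescence, with a stated time of 40 min; on this read-out higher numbers stand for weaker inhibition and lower numbers for stronger inhibition:
compound 1 `Cc1c(C(=O)O)ccn1-c1ccccc1` gives 3800 nM;
compound 2 `Cc1cc(C(=O)O)c(C)n1-c1ccc(Cl)c(C(F)(F)F)c1` gives 2100 nM;
compound 3 `Cc1cc(C(=O)O)c(C)n1-c1ccc(Cl)cc1` gives 860 nM.

Compound 3 and compound 2 differ in one place only: trifluoromethyl in place of hydrogen on an aromatic carbon The step is a 2.4-fold higher number from compound 3 to compound 2 (0.39 log units; beyond the scatter).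

Compound 4 `Cc1c(C(=O)O)cc(C(F)(F)F)n1-c1ccccc1` has not been measured. It comes from compound 1 by the same kind of change: trifluoromethyl in place of hydrogen on an aromatic carbon The surroundings are not the same: in the earlier pair the trifluoromethyl enters on a six-membered aromatic ring of carbon only, ortho to a chloro group; here it enters on a five-membered aromatic ring with 1 nitrogen, next to the ring nitrogen. How the core of compound 1 differs from the core of compound 3 is not broken down here. The values of compound 1 and compound 2 lie within the usual scatter of each other.

Because a 2.4-fold higher number from compound 3 to compound 2 (0.39 log units; beyond the scatter) ran toward weaker inhibition, a step of a 1.4-fold higher number from compound 1 to compound 4 (0.16 log units; within the scatter) is expected for compound 4 in this assay, held loose since the place differs. Compound 4 is estimated at 5500 nM, between 2000 nM and 15000 nM.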

Compound 4, half-maximal inhibitory concentration: 22000 nM
Estimate against measurement, compound 4: 4.0-fold (0.60 log units) below; measured number above the stated range.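

In this assay, trifluoromethyl in place of hydrogen on an aromatic carbon gives a 5.8-fold higher number from compound 1 to compound 4 (0.76 log units; beyond the scatter), which is toward weaker inhibition. The earlier pair ran the same way, and the two steps cannot be told apart in size: the same change on two cores in this assay, a 2.4-fold higher number (0.39 log units; beyond the scatter) from compound 3 to compound 2 and a 5.8-fold higher number (0.76 log units; beyond the scatter) from compound 1 to compound 4, 2.4-fold (0.37 log units) apart, within the scatter of two such steps. The change therefore carried over in direction on the two cores shown, but two pairs make no rule, and since the group enters a different ring in each pair, they do not separate the role of the core from that of the place.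

The compounds shown leave open how a nitrile or an amine on that same ring carbon of the core of compound 1 would read in this assay. They also leave open what trifluoromethyl on the phenyl group of compound 1 would do.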